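The source may report more compounds than this note shows. Statements on the series, on what has been measured and on what is new or still open speak of the compounds shown alone.

Measured compounds:
compound 1 `Nc1cc(N)c2nc(-c3ccccc3)c(Oc3ccc(Cl)c(Cl)c3)nc2c1` — 11500 nM
compound 2 `CCOC(=O)[C@H](CCC(=O)O)NC(=O)c1ccc(CNc2nc3cc(N)cc(N)c3nc2-c2ccccc2)cc1` — < 100000 nM
compound 3 `CCOC(=O)[C@H](CCC(=O)O)NC(=O)c1ccc(Sc2nc3cc(N)cc(N)c3nc2-c2ccccc2)cc1` — 4790 nM

In a functional assay on IGROV-1 cells (Homo sapiens) for inhibition, read by sulforhodamine B assay, with a stated time of 48 h (on this read-out higher numbers stand for weaker inhibition of growth and lower numbers for stronger inhibition of growth), compound 1 gives 11500 nM, the higher of the two numbers reported. Compound 3 gives 4790 nM, a lower number and a gap beyond the usual scatter. For compound 2 the assay reports only a limit, < 100000 nM, and no number.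

Compound 4 `Nc1cc(N)c2nc(-c3ccccc3)c(NCc3ccc(F)cc3)nc2c1` differs from compound 1 by (4-fluorobenzyl)amino in place of 3,4-dichlorophenoxy on an aromatic carbon. For the measured compounds named here, no measured pair traces this change, so the direction rests on the neighbours alone. Compound 4 is expected to sit near compound 1, with the step from compound 1 to compound 4 estimated as a 1.3-fold higher number from compound 1 to compound 4 (0.12 log units; within the scatter). The estimate for compound 4 is 15000 nM, within a range from 4000 nM to 60000 nM.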

Compound 4, concentration for 50% growth inhibition: 3090 nM
Estimate against measurement, compound 4: 4.9-fold (0.69 log units) above; measured number below the stated range.
By their numbers in this assay, from the lowest: compounds 4 and 3 (each within the scatter of the next); then compound 1.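

In this assay, for the compounds shown here, the step of a 3.7-fold lower number from compound 1 to compound 4 (0.57 log units; beyond the scatter) is the first reading of a change on this aromatic carbon next to the ring nitrogen, and it shows that the group held there affects growth inhibition. The entering (4-fluorobenzyl)amino carries a hydrogen-bond donor, which the leaving 3,4-dichlorophenoxy lacks, but several features change at once. Nothing shown accounts for the step.

Which feature matters remains open: a 4-fluorophenoxy or an unsubstituted benzylamino group at this position would separate the linking atom from the ring substituents.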